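Working notes: swapping the bicyclic group on the amine nitrogen

The compounds below may be only part of what the source reports. "The series", "measured", "known", "first", "only" and "open" are said of these compounds alone.

compound 1 `Cn1c(=O)c(S(=O)(=O)c2ccc(F)cc2F)cc2cnc(Nc3ccc4sccc4c3)nc21` gives 500 nM
compound 2 `Cn1c(=O)c(S(=O)(=O)c2ccc(F)cc2F)cc2cnc(Nc3cnc4[nH]ccc4c3)nc21` gives 750 nM

In a functional assay on DU-145 cells (Homo sapiens) for inhibition, read by trypan blue exclusion, with a stated time of 72 h (on this read-out lower numbers stand for stronger inhibition and higher numbers for weaker inhibition), compound 2 stands within the scatter of compound 1, so these two numbers show no order. The next change leads to compound 3 `Cc1cc2cc(Nc3ncc4cc(S(=O)(=O)c5ccc(F)cc5F)c(=O)n(C)c4n3)ccc2[nH]1` and is this: a group of 10 heavy atoms (9 carbon, 1 nitrogen; one five-membered aromatic ring with 1 hetero atom, one six-membered aromatic ring of carbon only) in place of a group of 9 heavy atoms (7 carbon, 2 nitrogen; one five-membered aromatic ring with 1 hetero atom, one six-membered aromatic ring with 1 hetero atom), on a nitrogen on an aromatic ring. Within the data shown here, the one measured step bearing on it also exchanged the bicyclic group on a nitrogen on an aromatic ring: a 1.5-fold higher number from compound 1 to compound 2 (0.18 log units; within the scatter). Among the measured compounds shown here, the entering 2-methyl-1H-indol-5-yl group has no measured precedent, so this single step is thin support. No shift beyond the scatter is expected in this assay, in either direction. The estimated step is a 1.3-fold lower number from compound 2 to compound 3 (0.10 log units; within the scatter). Compound 3 is estimated at 600 nM, with an expected range of 200 nM to 1800 nM.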

Compound 3, half-maximal inhibitory concentration: 750 nM
Estimate against measurement, compound 3: 1.3-fold (0.10 log units) below; measured number inside the range.
By their numbers in this assay, from the lowest: compounds 1, 2 and 3 (each within the scatter of the next).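

Notes on the amine nitrogen: in this assay the 2-methyl-1H-indol-5-yl group brings no shift beyond the scatter (no change at the digits printed from compound 2 to compound 3 (within the scatter)), even though the entering group has one more heavy atom and a six-membered aromatic ring of carbon only, and its count of hydrogen-bond acceptors falls to 0 while its hydrogen-bond donor stays. Against 1-benzothiophen-5-yl the picture is the same (a 1.5-fold higher number from compound 1 to compound 3 (0.18 log units; within the scatter)), so the three bicyclic groups now shown on this nitrogen do not separate in this read-out. No measurement on hand explains this flat result.

Still open, going by these compounds, is whether a group of another kind on this nitrogen, such as a plain phenyl ring or a longer chain ending in an amine or a carboxylic acid, would move the number beyond the scatter. Whether any change here can do so at all also remains unsettled.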